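Lipophilicity of a carbamate analogue in the series

A few compounds are considered here, and "the series" means these few. Any claim that something is new, unique, unknown or untested is made for them only; others in the source may bear on it.

Compound 1 `Cc1cc(C(=O)NCc2cccnc2)nn1Cc1cc(Cl)ccc1OCc1ccccc1` is the reference point. In a physicochemical assay for lipophilicity, at pH 7.4 (on this read-out higher numbers stand for higher lipophilicity and lower numbers for lower lipophilicity), compound 1 gives > 3.7, which is a limit of the measurement and not a number. For the measured compounds named here, compound 2 `Cc1cc(NC(=O)C2CCCCC2)nn1Cc1cc(Cl)ccc1OCC(C)C` is the only other measured member. In this assay compound 2 gives > 3.7, again a limit rather than a number. Going by the values given here, the two values therefore tell only that both compounds sit at the same limit (the limit of > 3.7 in this assay, at which 2 of the 2 values shown sit); no step between measured compounds can be stated.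

Compound 3 `Cc1cc(NC(=O)OCc2ccccc2)nn1Cc1cc(Cl)ccc1OCc1ccccc1` is not yet measured. It differs from compound 1 by (benzyloxycarbonyl)amino in place of ((pyridin-3-yl)methyl)carbamoyl on an aromatic carbon. With both known values already at the limit, no direction for the step can be read from the data; the step from compound 1 to compound 3 is expected to be a step that the limit leaves unreadable from compound 1 to compound 3, most likely again reported only as a limit. Compound 3 is estimated at 4.5, within 3.9 to 5.2.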

Compound 3, distribution coefficient: 3.1
Beside the measured number, compound 3's estimate is 1.40 log units above it; measured number outside the range, below it.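

Compound 3 gives 3.1 in this assay, the only true number among the compounds shown. Placing (benzyloxycarbonyl)amino in place of ((pyridin-3-yl)methyl)carbamoyl on this aromatic carbon gives a number at least 0.60 log units lower from compound 1 to compound 3 (beyond the scatter), which shows that the group at this position can move the read-out by more than the scatter. The size of that step is only a bound, and its true extent stays open: the limit of > 3.7 in this assay, at which 2 of the 3 values shown sit.

The change replaces the linking atoms and the terminal ring at once, so their shares cannot be separated, and the steps involving compound 2 cannot be read. From the compounds shown here alone, how an amine or a carboxylic acid on this aromatic carbon would read in this assay also stays open.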